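Nitrophenyl Oxadiazole Amides Against Histone Deacetylase 8

The compounds below may be only part of what the source reports. "The series", "measured", "known", "first", "only" and "open" are said of these compounds alone.

Compound 1 `O=C(CCCCCCc1nc(-c2cccc([N+](=O)[O-])c2)no1)NO`: in an assay on isolated protein for inhibition of histone deacetylase 8 (Homo sapiens), read by fluorescence, with a stated time of 10 min (a higher number here means a weaker inhibitor, a lower number a stronger inhibitor), compound 1 gives 2380 nM.
Compound 2 `Nc1ccccc1NC(=O)CCCCCCc1nc(-c2ccccc2Cl)no1`: in this assay compound 2 gives > 10000 nM, a limit of the assay.
Compound 3 `Nc1ccccc1NC(=O)CCCCCCc1nc(-c2ccc([N+](=O)[O-])cc2)no1`: in this assay compound 3 gives > 10000 nM, a limit of the assay.

Compound 3 stands at the limit of this assay, and compound 2 stands at that same limit, so only compound 1 carries a number. Among the compounds with values here, the single measured step, a step that the two limits leave unreadable from compound 2 to compound 3, runs from one limit to the other and its size cannot be read. Compound 4 `Nc1ccccc1NC(=O)CCCCCCc1nc(-c2cccc([N+](=O)[O-])c2)no1` differs from compound 3 by 3-nitrophenyl in place of 4-nitrophenyl on an aromatic carbon. Within the data shown here, no measured step bears on this change with a number at both ends, because the limit of > 10000 nM in this assay, at which 2 of the 3 values shown sit, swallows the two values that would frame it. Among the measured compounds shown here, with compound 3 at the limit, the step that the limit leaves unreadable from compound 3 to compound 4 is expected to leave compound 4 at or near that limit, since nothing among the measured values points to a reading inside the scale. Compound 4 is therefore expected to give about 15000 nM, with a range from 5000 nM to 50000 nM.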

Compound 4, half-maximal inhibitory concentration: > 10000 nM
Compound 4 gave a limit, no number; the forecaster's own chance of this, stated with the estimate: 75%; the middle value does not contradict the limit.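

Compound 4 also sits at a limit of the assay, with > 10000 nM in this assay, so moving the nitro group from 4-nitrophenyl to 3-nitrophenyl brings no reading inside the scale. The steps among compound 2, compound 3 and compound 4 cannot be read, because all three end at the same limit: the limit of > 10000 nM in this assay, at which 3 of the 4 values shown sit.

Within the data shown here, with 3-nitrophenyl held in common, the one readable comparison is an at least 4.2-fold higher number from compound 1 to compound 4 (0.62 log units; beyond the scatter), with 2-aminophenyl in place of hydroxy on an amide-type nitrogen. Among these compounds, the hydroxy compound therefore gives the only value on the scale.

Going by these compounds, it remains open whether 4-nitrophenyl and 3-nitrophenyl differ when hydroxy stands on that nitrogen. On these data alone, it is also open whether a methoxy group on the phenyl ring, or a longer chain, would bring a 2-aminophenyl amide inside the scale.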